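Bromophenyl chalcone amides: positional isomer, Vero cytotoxicity

The compounds below may be only part of what the source reports. "The series", "measured", "known", "first", "only" and "open" are said of these compounds alone.

Three members of the series share one core, carrying a chalcone-type arm with a varied aryl ring on the carbonyl carbon. Compound 1 is `COC(=O)c1cc(-c2cccc(NC(=O)c3ccc(/C=C/C(=O)c4cccc(Cl)c4)cc3)c2)on1`, compound 2 is `COC(=O)c1cc(-c2cccc(NC(=O)c3ccc(/C=C/C(=O)c4cccc([N+](=O)[O-])c4)cc3)c2)on1` and compound 3 is `COC(=O)c1cc(-c2cccc(NC(=O)c3ccc(/C=C/C(=O)c4cccc(Br)c4)cc3)c2)on1`. In an ADME assay on Vero cells (Chlorocebus sabaeus) for cytotoxicity, read by MTT assay, with a stated time of 72 h (on this read-out higher numbers stand for lower toxicity in this test and lower numbers for higher toxicity in this test), compound 1 reaches only a limit, > 2.5 ug/mL. In this assay compound 2 likewise gives a limit, > 40 ug/mL. In this assay compound 3 also stops at a limit, > 100 ug/mL. Because all three values are limits (the limit of > 100 ug/mL in this assay, at which 1 of the 3 values shown sits), the limit of > 2.5 ug/mL in this assay, at which 1 of the 3 values shown sits, and (the limit of > 40 ug/mL in this assay, at which 1 of the 3 values shown sits), none of the steps can be read: a step that the two limits leave unreadable from compound 1 to compound 2, a step that the two limits leave unreadable from compound 1 to compound 3 and a step that the two limits leave unreadable from compound 2 to compound 3. Where compound 3 stands is therefore known only as a limit, the highest of the three shown.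

Compound 4 is `COC(=O)c1cc(-c2cccc(NC(=O)c3ccc(/C=C/C(=O)c4ccccc4Br)cc3)c2)on1`. Its difference from compound 3 is 2-bromophenyl in place of 3-bromophenyl on a carbonyl carbon. Within the data shown here, no measured step bears on this change, and the three unreadable steps give no size to carry over. The expected step in this assay is none beyond the scatter, a number no higher from compound 3 to compound 4 (the limit leaves the size open), resting on the limit of compound 3 alone. Compound 4 is estimated at 100 ug/mL in this assay, with a range from 30 ug/mL to 300 ug/mL, and most likely reported again as a limit.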

Compound 4, half-maximal cytotoxic concentration: > 40 ug/mL
Compound 4: only a limit was reported; the forecaster's own chance of this, stated with the estimate: 60%; the middle value does not contradict the limit.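

In this assay compound 4 gives > 40 ug/mL, which is a limit. All four values are limits, and the steps from compound 1, compound 2 and compound 3 to compound 4 cannot be read. The compounds shown leave open whether 2-bromophenyl in place of 3-bromophenyl on a carbonyl carbon shifts the half-maximal cytotoxic concentration at all, and how the four compounds rank.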